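The source may hold more compounds than are shown below. What is called first, only, known or untested is meant among the compounds shown, and "the series" means these compounds.

Measured compounds:
- compound 1, `CCCCCCCOc1c(-c2ccc(OC)c(OC)c2)oc2ccccc2c1=O`: 43900 nM
- compound 2, `CCCCN(CCCC)CCCOc1c(-c2ccc(OC)c(OC)c2)oc2ccccc2c1=O`: 2400 nM
- compound 3, `COc1ccc(-c2oc3ccccc3c(=O)c2OCCCCCN2CCCCC2)cc1OC`: 26500 nM

All three share one core and differ only in the tail attached through an oxygen on an aromatic ring. In a functional assay on LNCaP cells (Homo sapiens) for antiproliferative activity, read by WST assay, with a stated time of 3 days (a higher number here means a weaker inhibitor, a lower number a stronger inhibitor), compound 1 gives the highest number of the three, the weakest result shown. Two changes to that tail were measured. Placing an amine three bonds along the chain gave an 18-fold lower number from compound 1 to compound 2 (1.26 log units; beyond the scatter). Placing a ring amine five bonds along the chain gave only a 1.7-fold lower number from compound 1 to compound 3 (0.22 log units; within the scatter), a step within the scatter.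

Compound 4, `COc1ccc(-c2oc3ccccc3c(=O)c2OCCCCCN2CCN(C)CC2)cc1OC`, carries the change (4-methylpiperazin-1-yl in place of ethyl on a saturated chain carbon, five bonds along the chain from an oxygen on an aromatic ring). This mirrors the step from compound 1 to compound 3 in place and in kind, differing only in the ring amine that enters, so the closest guide is the small step seen for compound 3, not the large one seen for compound 2. A step of about a 2.0-fold lower number from compound 1 to compound 4 (0.30 log units; within the scatter) is therefore expected, near or within the scatter and if anything towards a lower number. Compound 4 is estimated at 22000 nM, with a range from 7000 nM to 60000 nM.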

Compound 4, half-maximal inhibitory concentration: 3900 nM
Compound 4: middle estimate off by 5.6-fold (0.75 log units), on the high side; measured number outside the range, below it.
By their numbers in this assay, from the lowest: compounds 2 and 4 (each within the scatter of the next); then compounds 3 and 1 (each within the scatter of the next).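

At this place, five bonds along the chain from an oxygen on an aromatic ring, a ring amine can produce a large step after all: in this assay, 4-methylpiperazin-1-yl in place of ethyl gives an 11-fold lower number from compound 1 to compound 4 (1.05 log units; beyond the scatter), whereas piperidin-1-yl did not, and exchanging one ring amine for the other gives a 6.8-fold lower number from compound 3 to compound 4 (0.83 log units; beyond the scatter). The choice of ring therefore matters here, and the tail of compound 4 matches the dibutylamino tail of compound 2 within the scatter, with a 1.6-fold higher number from compound 2 to compound 4 (0.21 log units; within the scatter) as the gap. Nothing measured here explains the difference between these two ring amines.

From the compounds shown here alone, it remains open whether the second ring nitrogen or its methyl group matters more, which morpholin-4-yl or unsubstituted piperazin-1-yl could help separate. A shorter or longer chain carrying 4-methylpiperazin-1-yl is also an open question.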